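The compounds below may be only part of what the source reports. "The series", "measured", "known", "first", "only" and "open" are said of these compounds alone.

Measured compounds:
- compound 1 `O=S(=O)(/C=C/c1ccccn1)c1ccccc1Cl`: 618 nM
- compound 2 `O=S(=O)(/C=C/c1ccc(Cl)nc1)c1ccccc1F`: 2550 nM
- compound 3 `O=S(=O)(/C=C/c1cccnc1)c1ccccc1Cl`: 2850 nM

In an assay on U2OS cells for activation of nuclear factor erythroid 2-related factor 2 (Homo sapiens), read by beta-arrestin recruitment, with a stated time of 6 h (a lower number here means that less compound is needed, a higher number that more compound is needed for the effect), compound 3 gives the highest of the three numbers. Its nearest neighbour is compound 2, whose value lies within the scatter of that of compound 3, so no order between the two can be read. Going by the values given here, the distance to compound 1 is the one clear step: a 4.6-fold higher number from compound 1 to compound 3 (0.66 log units; beyond the scatter).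

Compound 4 `O=S(=O)(/C=C/c1ccc(Cl)nc1)c1ccccc1Cl` is not yet measured. It is derived from compound 3 by the change (chloro in place of hydrogen on an aromatic carbon). Among the compounds with values here, no measured step bears directly on this change; the only step on record, from compound 1 to compound 3, concerns the pyridinyl attachment and not a substituent on it. Compound 2, which already carries the chloro-bearing pyridinyl ring of compound 4 but differs from it elsewhere, gives a value within the scatter of that of compound 3. On that basis no step beyond the scatter is expected in this assay for compound 4; the estimated step is a 1.1-fold lower number from compound 3 to compound 4 (0.02 log units; within the scatter). Compound 4 is therefore expected to give about 2700 nM, with a plausible range of 1200 nM to 6500 nM.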

Compound 4, half-maximal effective concentration: 1630 nM
Estimate against measurement, compound 4: 1.7-fold (0.22 log units) above; low and high end bracket the measured number.
By their numbers in this assay, from the lowest: compound 1; then compounds 4, 2 and 3 (each within the scatter of the next).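

In this assay, going by these compounds alone, chloro in place of hydrogen on an aromatic carbon, next to the ring nitrogen, gives (a 1.7-fold lower number from compound 3 to compound 4 (0.24 log units; within the scatter)), so on this pyridin-3-yl ring the position accepts chloro with no step that can be read. Chloro in place of fluoro on an aromatic carbon of the other ring also gives no readable step (a 1.6-fold lower number from compound 2 to compound 4 (0.19 log units; within the scatter)), which leaves the pyridinyl attachment (a 4.6-fold higher number from compound 1 to compound 3 (0.66 log units; beyond the scatter)) as the only change so far with a step beyond the scatter. No measurement at hand explains either result.

Still open, from the compounds shown here alone, is whether a larger or different group at the same carbon, such as an amine, a methoxy group or a carboxylic acid, would give a step beyond the scatter in this assay rather than the small difference seen with chloro. Also open, going by these compounds, is whether chloro on the pyridin-2-yl ring of compound 1 would stay within the scatter as it does on the pyridin-3-yl ring.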